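Swapping trifluoromethyl for acetoxy on the aromatic ring

The source may hold more compounds than are shown below. What is called first, only, known or untested is meant among the compounds shown, and "the series" means these compounds.

Compound 1 `COC(=O)C1=C(C)N=C(C)/C(=C(\O)OC)C1c1cccc(O)c1`, compound 2 `COC(=O)C1=C(C)N=C(C)/C(=C(\O)OC)C1c1cccc(N(C)C)c1` and compound 3 `COC(=O)C1=C(C)N=C(C)/C(=C(\O)OC)C1c1cccc(C(F)(F)F)c1` share one core and differ only in a single group on an aromatic carbon. In a functional assay (muscle tissue) with Cavia porcellus as the target (a higher number here means that more compound is needed for the effect, a lower number that less compound is needed), compound 1 gives 1000 nM and compound 2 gives 891 nM. Compound 3 gives 74.1 nM, the lowest of the three numbers.

The next compound is compound 4 `COC(=O)C1=C(C)N=C(C)/C(=C(\O)OC)C1c1cccc(OC(C)=O)c1`, which carries acetoxy in place of trifluoromethyl on that aromatic carbon: acetoxy in place of trifluoromethyl on an aromatic carbon.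

Going by the values given here, three measured steps bear on this change, although none of them involves acetoxy. Exchanging hydroxy for dimethylamino gave a 1.1-fold lower number from compound 1 to compound 2 (0.05 log units; within the scatter), so that exchange separates nothing here. Trifluoromethyl gave large steps: a 13-fold lower number from compound 1 to compound 3 (1.13 log units; beyond the scatter) and a 12-fold lower number from compound 2 to compound 3 (1.08 log units; beyond the scatter). Among the compounds with values here, compound 4 gives up the one group linked to a low number, and a step towards a higher number is expected in this assay. From the compounds shown here alone, whether acetoxy behaves like hydroxy or dimethylamino is unknown, and no measurement shows it, so only part of those large steps is assumed to return.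

The expected change is a 4.0-fold higher number from compound 3 to compound 4 (0.61 log units; beyond the scatter). For compound 4 the estimated value is 300 nM, with an expected range from 90 nM to 1000 nM.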

Compound 4, half-maximal effective concentration: 6030 nM
Compound 4: the middle estimate sits 20-fold (1.30 log units) below what was measured; the measured number lies above the stated range.
By their numbers in this assay, from the lowest: compound 3; then compounds 2 and 1 (each within the scatter of the next); then compound 4.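

In this assay acetoxy does not simply fall back to the level shared by hydroxy and dimethylamino: the loss of trifluoromethyl now appears as an 81-fold higher number from compound 3 to compound 4 (1.91 log units; beyond the scatter) and is the largest step in this small set, and the number also rises past both other groups, with a 6.8-fold higher number from compound 2 to compound 4 (0.83 log units; beyond the scatter) and a 6.0-fold higher number from compound 1 to compound 4 (0.78 log units; beyond the scatter) as the two further steps. The last of these is the most direct comparison. Adding an acetyl group to the oxygen of the hydroxy compound moves the number up rather than leaving it unchanged, so this position separates at least three levels and not just trifluoromethyl from everything else. Trifluoromethyl and acetoxy also bring the same count of heavy atoms, so that count alone does not separate the lowest number from the highest, and no measurement here gives a reason for the gap between them.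

From the compounds shown here alone, it remains open whether the high number goes with the acetyl group itself, which a methoxy group or an acetamide on the same aromatic carbon could help to test. Going by these compounds, it is also open whether a group such as chlorine or a nitrile could come close to the low number of trifluoromethyl.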